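Allyl to butyl on the amine nitrogen

The source may hold more compounds than are shown below. What is called first, only, known or untested is meant among the compounds shown, and "the series" means these compounds.

Values measured in a functional assay on CHO-K1 cells (Cricetulus griseus) for inhibition, read by MTT assay, with a stated time of 72 h (a higher number here means a weaker inhibitor, a lower number a stronger inhibitor), are as follows:
- compound 1 (`C=CCNC(=C\C(=O)/C=C/c1ccc(O)c(OC)c1)/C=C/c1ccc(O)c(OC)c1`) gives 7400 nM
- compound 2 (`CCC(C)NC(=C\C(=O)/C=C/c1ccc(O)cc1)/C=C/c1ccc(O)cc1`) gives 13100 nM
- compound 3 (`O=C(/C=C(/C=C/c1ccc(O)cc1)NC1CCCCC1)/C=C/c1ccc(O)cc1`) gives 9200 nM

Compound 1 lies within the scatter of compound 2 and of compound 3, so the three values do not separate. Compound 4 (`CCCCNC(=C\C(=O)/C=C/c1ccc(O)c(OC)c1)/C=C/c1ccc(O)c(OC)c1`) carries butylamino where compound 1 carries allylamino (propyl in place of vinyl on a saturated chain carbon bound to an amine nitrogen): propyl in place of vinyl on a saturated chain carbon bound to an amine nitrogen. Within the data shown here, the only measured change on that nitrogen, cyclohexyl in place of sec-butyl (a 1.4-fold lower number from compound 2 to compound 3 (0.15 log units; within the scatter)), stayed within the scatter, though on a core differing from that of compound 1. No step beyond the scatter is therefore expected in this assay, and the expected step is small (a 1.0-fold higher number from compound 1 to compound 4 (0.01 log units; within the scatter)). The estimated value for compound 4 is 7500 nM (range 3500 nM to 15000 nM).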

Compound 4, half-maximal inhibitory concentration: 7000 nM
Compound 4: middle estimate off by 1.1-fold (0.03 log units), on the high side; measured number inside the range.
By their numbers in this assay, from the lowest: compounds 4, 1, 3 and 2 (each within the scatter of the next).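

In this assay the change from allylamino to butylamino gives a 1.1-fold lower number from compound 1 to compound 4 (0.02 log units; within the scatter) on the core of compound 1. Among these compounds, this is the first step read at this nitrogen on that core, and it shows that the vinyl double bond can give way to a saturated propyl without the values separating. No measurement available here accounts for this result.

Still open, on these data alone, is whether a longer chain such as octyl, or a benzyl group, would stay within the scatter on this core. As far as these compounds go, a chain ending in a carboxylic acid or a primary amine is equally open.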